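Bromo added to the core of compound 2

The compounds below may be only part of what the source reports. "The series", "measured", "known", "first", "only" and "open" are said of these compounds alone.

In a functional assay on OVCAR-8 cells (Homo sapiens) (on this read-out lower numbers stand for stronger inhibition of growth and higher numbers for weaker inhibition of growth), compound 1 `O=S(=O)(/C=C/c1ccc(F)cc1)Cc1ccc(Nc2ncnc3ccccc23)cc1` gives 2000 nM, and compound 2 `O=S(=O)(/C=C/c1ccc(Br)cc1)Cc1ccc(Nc2ncnc3ccccc23)cc1` gives 38000 nM, the higher of the two actual numbers. Compound 3 `O=S(=O)(/C=C/c1ccc(F)cc1F)Cc1ccc(Nc2ncnc3ccccc23)cc1` reads > 100000 nM, which is a limit of the assay. Compound 4 `O=S(=O)(/C=C/c1ccc(Br)cc1)Cc1ccc(Nc2ncnc3ccc(Br)cc23)cc1` differs from compound 2 by bromo in place of hydrogen on an aromatic carbon, on the fused system. For the measured compounds named here, no measured step touches that system. The nearest guides are halogen changes on the other aromatic ring, a 19-fold higher number from compound 1 to compound 2 (1.28 log units; beyond the scatter) and an at least 50-fold higher number from compound 1 to compound 3 (1.69 log units; beyond the scatter), both towards weaker inhibition of growth. Their sizes transfer poorly to a new site, so only a modest move in the same direction is expected, namely a 1.4-fold higher number from compound 2 to compound 4 (0.16 log units; within the scatter). Compound 4 is estimated at 55000 nM, with an expected range of 15000 nM to 100000 nM.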

Compound 4, concentration for 50% growth inhibition: 2000 nM
Compound 4: the middle estimate sits 28-fold (1.44 log units) above what was measured; the whole stated range lies above it.
By their numbers in this assay, from the lowest: compounds 1 and 4 (each within the scatter of the next); then compound 2. At a limit, above all of these: compound 3.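

In this assay, bromo in place of hydrogen on the fused system gives a 19-fold lower number from compound 2 to compound 4 (1.28 log units; beyond the scatter), towards stronger inhibition of growth. For the compounds shown here, this is the only step at this position, and it shows that the site responds, with the number moving the opposite way from the halogen changes on the other aromatic ring. No measured property shown here accounts for this gain.

Going by these compounds, whether the gain is specific to bromo stays open: an amine, a methoxy group or a carboxylic acid on the same carbon would test this. Also open, on these data alone, is whether the gain persists with fluoro in place of bromo on the other aromatic ring.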